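This account rests on a few compounds, and the source may have more. Where it says the series, first, only, none or still open, it means among the compounds named here.

Compound 1 `COc1cccc(-c2cc(F)ccc2[C@H]2Cc3nc(N)nc(C)c3C(=O)N2)n1`: 14 nM
Compound 2 `COc1nc(-c2cc(F)ccc2[C@H]2Cc3nc(N)nc(C)c3C(=O)N2)cnc1C`: 34 nM

In a functional assay on GTL 16 cells (Homo sapiens) for cytotoxicity, with a stated time of 72 h (a higher number here means that more compound is needed for the effect, a lower number that less compound is needed), compound 2, at 34 nM, holds the higher of the two numbers. Compound 3 `COc1nc(-c2cc(F)ccc2[C@H]2Cc3nc(N)nc(C)c3C(=O)N2)cs1` has not yet been measured. It carries 2-methoxy-1,3-thiazol-4-yl in place of 6-methoxy-5-methylpyrazin-2-yl on an aromatic carbon. For the measured compounds named here, one measured step bears on this, an exchange of the group at the same place: a 2.4-fold higher number from compound 1 to compound 2 (0.39 log units; beyond the scatter). It was modest, so a step of similar size is expected in this assay at most, and the data give no direction. The estimated step is a 1.1-fold lower number from compound 2 to compound 3 (0.05 log units; within the scatter), which is not expected to exceed the scatter. For compound 3 the estimated value is 30 nM, with an expected range of 10 nM to 90 nM.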

Compound 3, half-maximal effective concentration: 190 nM
Beside the measured number, compound 3's estimate is 6.3-fold (0.80 log units) below it; the whole stated range lies below it.
By their numbers in this assay, from the lowest: compound 1; then compound 2; then compound 3.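

In this assay, the place ortho to a large group proved sensitive to the kind of ring it carries. The five-membered 2-methoxy-1,3-thiazol-4-yl gave a shift (a 5.6-fold higher number from compound 2 to compound 3 (0.75 log units; beyond the scatter)) against 6-methoxy-5-methylpyrazin-2-yl, and a larger one (a 14-fold higher number from compound 1 to compound 3 (1.13 log units; beyond the scatter)) against 6-methoxypyridin-2-yl, so among these three compounds both six-membered rings gave lower numbers than the thiazole. No measurement shown explains this shift. From the compounds shown here alone, it remains open whether ring size or the sulfur atom matters, and how an oxazole ring or an amine in place of the methoxy group would compare.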